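A few compounds are considered here, and "the series" means these few. Any claim that something is new, unique, unknown or untested is made for them only; others in the source may bear on it.

Measured so far in a functional assay on HCT-116 cells (Homo sapiens) for inhibition, read by CCK-8 assay, with a stated time of 48 h (a lower number here means a stronger inhibitor, a higher number a weaker inhibitor), are three compounds:

compound 1 `COc1cc(-c2ccnc3cc(-c4ccc(F)cc4)nn23)cc(OC)c1OC` gives 5030 nM
compound 2 `COc1cc(-c2ccnc3cc(-c4c[nH]c5ccccc45)nn23)cc(OC)c1OC` gives 35 nM
compound 3 `COc1cc(-c2ccnc3cc(-c4ccccc4)nn23)cc(OC)c1OC` gives 3880 nM

Compound 3 sits level with compound 1, and the data show a 1.3-fold lower number from compound 1 to compound 3 (0.11 log units; within the scatter) with no real gap between them. Compound 2 stands far off, with a 110-fold higher number from compound 2 to compound 3 (2.04 log units; beyond the scatter) as a large step.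

Compound 4 `COc1cc(-c2ccnc3cc(-c4ccc5cc[nH]c5c4)nn23)cc(OC)c1OC` comes from compound 3 by the change 1H-indol-6-yl in place of phenyl on an aromatic carbon in which 1H-indol-6-yl stands in place of phenyl on an aromatic carbon. The closest guides are the two large steps involving 1H-indol-3-yl, namely a 110-fold higher number from compound 2 to compound 3 (2.04 log units; beyond the scatter) and a 140-fold lower number from compound 1 to compound 2 (2.16 log units; beyond the scatter) in the same direction of gain for the indole. Within the data shown here, no measured compound carries 1H-indol-6-yl, so how much of that gain carries over is unknown. A move to a lower number is therefore expected, but a smaller one than compound 2 showed.

In this assay the estimated step is a 9.7-fold lower number from compound 3 to compound 4 (0.99 log units; beyond the scatter) as an expectation only. For compound 4 the estimate is 400 nM with an expected range from 50 nM to 3000 nM for a measurement.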

Compound 4, half-maximal inhibitory concentration: 187 nM
Beside the measured number, compound 4's estimate is 2.1-fold (0.33 log units) above it; the range from low to high includes it.
By their numbers in this assay, from the lowest: compound 2; then compound 4; then compounds 3 and 1 (each within the scatter of the next).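

In this assay, the gain at this aromatic carbon is not unique to 1H-indol-3-yl: 1H-indol-6-yl also brings a 21-fold lower number from compound 3 to compound 4 (1.32 log units; beyond the scatter) and a 27-fold lower number from compound 1 to compound 4 (1.43 log units; beyond the scatter) against the two groups with a single ring. The point at which the indole is joined to the core still counts, with a 5.3-fold higher number from compound 2 to compound 4 (0.73 log units; beyond the scatter) when 1H-indol-6-yl replaces 1H-indol-3-yl, so the two indoles are not interchangeable. No measurement at hand explains either the gain or this difference between the two indoles.

On these data alone, it remains open whether the gain depends on the hydrogen on the indole's ring nitrogen or simply on having a second fused ring. A naphthyl group, or an indole with a methyl on that nitrogen, would help separate these two possibilities.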